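Protein disulfide-isomerase series: aryl exchange at the aminomethine carbon

The source may hold more compounds than are shown below. What is called first, only, known or untested is meant among the compounds shown, and "the series" means these compounds.

Measured so far:
compound 1, `O=[N+]([O-])c1ccc(C(c2c(O)ccc3[nH]ncc23)N2CCCCC2)cc1`, 520 nM
compound 2, `Oc1cc(F)ccc1C(c1ccc2ccoc2c1O)N1CCCCC1`, 1070 nM

In an assay for inhibition of protein disulfide-isomerase (Homo sapiens), with a stated time of 1 h (a lower number here means a stronger inhibitor, a higher number a weaker inhibitor), compound 2 gives the higher of the two numbers; compound 1 gives the lower one, and that gap lies beyond the usual scatter. Compound 3, `Oc1c(C(c2ccncc2)N2CCCCC2)ccc2ccoc12`, is not yet measured. It differs from compound 2 in one place: pyridin-4-yl in place of 4-fluoro-2-hydroxyphenyl on a saturated chain carbon bound to an amine nitrogen in a ring and an aromatic carbon. Going by the values given here, no step between measured compounds covers this change, so the expectation rests on compound 2 alone. A modest move toward a weaker inhibitor is expected, a 1.9-fold higher number from compound 2 to compound 3 (0.27 log units; within the scatter), since the hydrogen-bond donor of the leaving group is lost. Compound 3 is therefore estimated at 2000 nM, with a range from 700 nM to 6000 nM.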

Compound 3, half-maximal inhibitory concentration: < 200 nM
Compound 3: no number, only a limit; the forecaster's own chance of this, stated with the estimate: 10%; middle value at least 10-fold (1.00 log units) away from the limit.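

In this assay, pyridin-4-yl in place of 4-fluoro-2-hydroxyphenyl on this saturated chain carbon gives an at least 5.3-fold lower number from compound 2 to compound 3 (0.72 log units; beyond the scatter). The hydrogen-bond donor of the leaving group is therefore not needed here for a stronger inhibitor, at least in this pair. Compound 3 carries a limit and not a number: the limit of < 200 nM in this assay, at which 1 of the 3 values shown sits.

The exchange removes the hydroxyl and the fluorine and adds the ring nitrogen all at once, so the step cannot be assigned to any one of them. Going by these compounds, whether plain phenyl or pyridin-3-yl would match pyridin-4-yl remains open.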